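The source may hold more compounds than are shown below. What is called first, only, known or untested is meant among the compounds shown, and "the series" means these compounds.

Measured compounds:
compound 1, `Nc1nnc(SC[C@H]2O[C@@H](OCc3noc(-c4ccc([N+](=O)[O-])cc4)n3)[C@@H]3OC4(CCCC4)O[C@@H]32)s1`, 28000 nM
compound 2, `COc1cc(-c2nc(CO[C@@H]3O[C@H](CSc4nnc(N)s4)[C@H]4OC5(CCCC5)O[C@@H]34)no2)cc(OC)c1OC`, 31000 nM

Both compounds were tested in a functional assay on HeLa cells (Homo sapiens) for antiproliferative activity, read by sulforhodamine B assay, with a stated time of 48 h; on this read-out lower numbers stand for stronger inhibition of growth and higher numbers for weaker inhibition of growth. Among the measured compounds shown here, compound 1 holds the lowest of the two numbers, but the only measured step, a 1.1-fold higher number from compound 1 to compound 2 (0.04 log units; within the scatter), is within the scatter, so compound 1 and compound 2 cannot be told apart on this read-out; both inhibit growth only weakly.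

Compound 3, `Cc1ccc(S(=O)(=O)OC[C@H]2O[C@@H](OCc3noc(-c4ccc([N+](=O)[O-])cc4)n3)[C@@H]3OC4(CCCC4)O[C@@H]32)cc1`, differs from compound 1 by ((4-methylphenyl)sulfonyl)oxy in place of (5-amino-1,3,4-thiadiazol-2-yl)sulfanyl on a saturated chain carbon bound to a saturated ring carbon. For the measured compounds named here, the one measured step concerns an exchange of the aryl group on the oxadiazole, a different part of the shared core, and it was within the scatter; no measured step touches the side of the molecule altered here. There is therefore no measured basis for expecting movement in either direction, and the two measured compounds show that this core, with either aryl group, gives high numbers in this assay. On that ground compound 3 is expected to stay close to compound 1, with an estimated step of a 1.3-fold higher number from compound 1 to compound 3 (0.10 log units; within the scatter). The estimate for compound 3 is 35000 nM, within a range from 8000 nM to 150000 nM.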

Compound 3, concentration for 50% growth inhibition: > 100000 nM
Compound 3 gave a limit, no number; the forecaster's own chance of this, stated with the estimate: 30%; at least 2.8-fold (0.45 log units) between middle value and limit.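

In this assay, the side of the molecule that the earlier pair left unchanged proves able to move the read-out: ((4-methylphenyl)sulfonyl)oxy in place of (5-amino-1,3,4-thiadiazol-2-yl)sulfanyl on a saturated chain carbon bound to a saturated ring carbon gives an at least 3.5-fold higher number from compound 1 to compound 3 (0.55 log units; beyond the scatter). Among the compounds shown, this is the first single change to lie beyond the scatter, whereas the aryl exchange between compound 1 and compound 2 did not, and its direction is toward weaker inhibition of growth. Compound 3 reads > 100000 nM, which is a limit of the assay and not a number, so the full size of the step stays unknown: the limit of > 100000 nM in this assay, at which 1 of the 3 values shown sits.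

The compounds shown leave open which part of the (5-amino-1,3,4-thiadiazol-2-yl)sulfanyl group matters, and whether a simple amine, a hydroxyl or a carboxylic acid on this chain carbon would give a number closer to that of compound 1 or that of compound 3. They also leave open whether the same exchange would have a similar effect with the 3,4,5-trimethoxyphenyl group of compound 2, and whether any group at this place could give a clearly lower number than compound 1 does.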